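The compounds below may be only part of what the source reports. "The series", "measured", "known", "first", "only" and "open" are said of these compounds alone.

Measured compounds in a functional assay on Jurkat cells (Homo sapiens) for inhibition; on this read-out higher numbers stand for weaker inhibition and lower numbers for stronger inhibition:
Compound 1 `C[C@H](NC(=O)C(=O)NC1CCCCC1)C(=O)N[C@@H](CC(=O)O)C(=O)COc1c(F)c(F)cc(F)c1F` gives 150 nM.
Compound 2 `C[C@H](NC(=O)C(=O)NCc1ccccc1)C(=O)N[C@@H](CC(=O)O)C(=O)COc1c(F)c(F)cc(F)c1F` gives 300 nM.
Compound 3 `C[C@H](NC(=O)C(=O)Nc1ccccc1F)C(=O)N[C@@H](CC(=O)O)C(=O)COc1c(F)c(F)cc(F)c1F` gives 160 nM.

Compound 3 stands second highest of the three numbers in this assay; its nearest neighbour is compound 1, a 1.1-fold higher number from compound 1 to compound 3 (0.03 log units; within the scatter), and its furthest is compound 2, a 1.9-fold lower number from compound 2 to compound 3 (0.27 log units; within the scatter). All three share the same core and differ only in the group on an amide-type nitrogen.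

Compound 4 `C[C@H](NC(=O)C(=O)Nc1ccccc1Cc1ccccc1)C(=O)N[C@@H](CC(=O)O)C(=O)COc1c(F)c(F)cc(F)c1F` is built on compound 3, where (benzyl in place of fluoro on an aromatic carbon). Within the data shown here, no measured step matches this change exactly. Among the measured compounds shown here, the steps that bear on it are the exchanges of the group on that nitrogen: a 2.0-fold higher number from compound 1 to compound 2 (0.30 log units; within the scatter), a 1.1-fold higher number from compound 1 to compound 3 (0.03 log units; within the scatter) and a 1.9-fold lower number from compound 2 to compound 3 (0.27 log units; within the scatter), each within the scatter. A benzyl and a 2-fluorophenyl on that nitrogen gave numbers in this assay close to one another, so attaching a benzyl onto the ring of compound 3 is expected to shift the number little, if at all, beyond the scatter, with a slight lean toward a higher number. The expected outcome is a 1.3-fold higher number from compound 3 to compound 4 (0.10 log units; within the scatter). The estimate for compound 4 in this assay is 200 nM, with a range from 80 nM to 550 nM.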

Compound 4, half-maximal inhibitory concentration: 10 nM
Estimate against measurement, compound 4: 20-fold (1.30 log units) above, and the stated range ends above it.
By their numbers in this assay, from the lowest: compound 4; then compounds 1, 3 and 2 (each within the scatter of the next).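

In this assay the replacement of fluoro by benzyl on an aromatic carbon, ortho to a large group, gives a 16-fold lower number from compound 3 to compound 4 (1.20 log units; beyond the scatter) and this is the only step among these compounds that lies beyond the scatter. The earlier exchanges among cyclohexyl, benzyl and 2-fluorophenyl on the amide-type nitrogen all stayed within the scatter, so this aromatic carbon responds to a change in a way those exchanges did not show, and a benzyl with its seven heavy atoms in place of a single fluorine goes with stronger inhibition rather than a loss of it. Nothing measured here accounts for why the number falls so far.

The compounds shown leave open whether the drop belongs to the benzyl itself or would also follow from a phenyl, a methyl or a longer chain such as phenylethyl on the same carbon. They also leave open whether an amine or a carboxylic acid on the incoming benzyl ring would keep the lower number, and whether a benzyl on another carbon of that ring would do the same.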